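Acetylation of the aniline nitrogen in a benzimidazole-type cytotoxicity series

The compounds below may be only part of what the source reports. "The series", "measured", "known", "first", "only" and "open" are said of these compounds alone.

Measured compounds:
compound 1, `Nc1ccc(-c2nc3cc(Cl)c(Cl)cc3[nH]2)cc1`: 17000 nM
compound 2, `CC(=O)Nc1ccc(-c2nc3cc(C(F)(F)F)ccc3n2C)cc1`: 15000 nM

In an ADME assay on MT4 cells (Homo sapiens) for cytotoxicity, read by MTT assay, with a stated time of 96 h (on this read-out lower numbers stand for higher toxicity in this test and higher numbers for lower toxicity in this test), compound 1 gives 17000 nM, the highest of the two numbers at hand. In this assay compound 2 gives 15000 nM, and the two values lie within the scatter of each other, so no ordering between compound 1 and compound 2 can be read from them. Within the data shown here, the two compounds differ in more than one place, so no single step is recorded between them.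

Compound 3, `CC(=O)Nc1ccc(-c2nc3cc(Cl)c(Cl)cc3[nH]2)cc1`, is not yet measured in this assay. It shares the core of compound 1 and differs from it by one change: acetyl in place of hydrogen on a nitrogen on an aromatic ring.

Among the measured compounds shown here, compound 2, which already carries the acetamido group, sits at a number indistinguishable from compound 1, and no other step is recorded, so the step from compound 1 to compound 3 is expected to be small, without a clear direction beyond the scatter; the expected step is a 1.2-fold higher number from compound 1 to compound 3 (0.07 log units; within the scatter). For compound 3 in this assay the estimate is 20000 nM, with a range from 9000 nM to 45000 nM.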

Compound 3, half-maximal cytotoxic concentration: > 100000 nM
Compound 3: no number, only a limit (the forecaster's own chance of this, stated with the estimate: 15%); middle value at least 5.0-fold (0.69 log units) from the limit.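

Compound 3 reads > 100000 nM in this assay, which is a limit of the assay and not a number. Amino to acetamido, on a nitrogen on an aromatic ring of the shared core, gives an at least 5.8-fold higher number from compound 1 to compound 3 (0.76 log units; beyond the scatter), which points toward lower toxicity in this test and lies beyond the scatter; compound 2, which differs from compound 1 in more than one place, could not isolate this change. As far as these compounds go, this single change therefore matters at this position, but the step has no upper end and its full size stays unknown: the limit of > 100000 nM in this assay, at which 1 of the 3 values shown sits.

Open, from the compounds shown here alone, is whether the shift belongs to acetyl in particular or would also follow from a methyl, a propanoyl chain or a methanesulfonyl group on the same nitrogen. Also open, going by these compounds, is whether the same change carries over to the core of compound 2, which would take the amino counterpart of compound 2 to decide, and whether a number for compound 3 could be obtained beyond the limit of the assay.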